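The source may report more compounds than this note shows. Statements on the series, on what has been measured and on what is new or still open speak of the compounds shown alone.

In a functional assay on MDA-MB-231 cells (Homo sapiens) for cytotoxicity, read by MTT assay, with a stated time of 72 h (on this read-out higher numbers stand for weaker inhibition and lower numbers for stronger inhibition), compound 2 (`CCN(CC)Cc1ccc2nc(NC(=O)N/N=C/c3cn(Cc4ccc(Cl)cc4Cl)c4ccccc34)sc2c1`) gives 3280 nM and sits level with compound 1 (`CC1CCN(Cc2ccc3nc(NC(=O)N/N=C/c4cn(Cc5ccc(Cl)cc5Cl)c5ccccc45)sc3c2)CC1`) at 3140 nM at the top of the three numbers. Compound 3 (`CN(C)Cc1ccc2nc(NC(=O)N/N=C/c3cn(Cc4ccccc4)c4ccccc34)sc2c1`) gives 1340 nM and lies lower, beyond the scatter. The next compound is compound 4 (`CCN(CC)Cc1ccc2nc(NC(=O)N/N=C/c3c[nH]c4ccccc34)sc2c1`), which differs from compound 2 by hydrogen in place of 2,4-dichlorobenzyl on an aromatic nitrogen in a single place. For the measured compounds named here, the only measured single-place step, a 1.0-fold higher number from compound 1 to compound 2 (0.02 log units; within the scatter) and within the scatter, concerns the diethylamino group and says nothing about this nitrogen. Going by the values given here, compound 3 also keeps a benzyl group there, so no measured compound shows that nitrogen bare, and no measured step sizes the change. The expectation is therefore a judgement resting on how much of the molecule leaves: a moderate move to a higher number, meaning weaker inhibition, with a 1.8-fold higher number from compound 2 to compound 4 (0.26 log units; within the scatter) as the estimated step and a wide margin. For compound 4 the expected value is 6000 nM with an estimated range from 1800 nM to 20000 nM in this assay when it is measured.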

Compound 4, half-maximal inhibitory concentration: 1900 nM
Estimate against measurement, compound 4: 3.2-fold (0.50 log units) above, and the stated range covers the measured number.
By their numbers in this assay, from the lowest: compounds 3, 4, 1 and 2 (each within the scatter of the next, the first and the last beyond it).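

In this assay, hydrogen in place of 2,4-dichlorobenzyl on the aromatic nitrogen gives a 1.7-fold lower number from compound 2 to compound 4 (0.24 log units; within the scatter). For the compounds shown here, this is the first view of that nitrogen bare, and it shows that all 9 heavy atoms of the group, with its six-membered aromatic ring, can leave without a step beyond the scatter, so in this pair the group is not required for a number in this range. The data offer no independent measurement that could account for this result.

On these data alone, it remains open whether a methyl group, or a longer chain ending in an amine, on this nitrogen would move the number beyond the scatter of compound 4. As far as these compounds go, it also remains open whether hydrogen on this nitrogen would give the same result with 4-methylpiperidin-1-yl in place of diethylamino.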